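The source may hold more compounds than are shown below. What is called first, only, known or untested is meant among the compounds shown, and "the series" means these compounds.

Measured compounds:
compound 1, `FC(F)(F)c1ccc(CSc2nc(Nc3cccc(Br)c3)c3ccccc3n2)cc1`, in a functional assay on MGC-803 cells (Homo sapiens) for cytotoxicity, read by MTT assay, with a stated time of 72 h (on this read-out lower numbers stand for stronger inhibition and higher numbers for weaker inhibition), gives 23700 nM.
compound 2, `O=[N+]([O-])c1cccc(Nc2nc(SCc3ccc(C(F)(F)F)cc3)nc3ccccc23)c1`, in this assay gives only a limit, > 50000 nM.

Compound 2 stands at the upper edge of the numbers shown: its value is a limit of the assay, not a number, and it carries the larger of the two results. Among the measured compounds shown here, the one measured step, bromo to nitro, runs an at least 2.1-fold higher number from compound 1 to compound 2 (0.32 log units; beyond the scatter), and its end point sits at the limit of > 50000 nM in this assay, at which 1 of the 2 values shown sits.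

Compound 3, `O=[N+]([O-])c1ccc(Nc2nc(SCc3ccc(C(F)(F)F)cc3)nc3ccccc23)cc1`, differs from compound 2 by 4-nitrophenyl in place of 3-nitrophenyl on a nitrogen on an aromatic ring. For the measured compounds named here, no measured step concerns a move of a group from one position to another; the single step in hand exchanges one group for another on the same ring and so gives no direction for this change. With compound 2 already at a limit, compound 3 is expected near the same place, about 60000 nM, range 20000 nM to 200000 nM. That estimate means a step that the limit leaves unreadable from compound 2 to compound 3, and a second limit is expected to be the most likely outcome.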

Compound 3, half-maximal inhibitory concentration: 8170 nM
Compound 3: middle estimate off by 7.3-fold (0.87 log units), on the high side, outside the stated range (below it).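

In this assay, the place of the nitro group on the ring carried by the nitrogen matters: 4-nitrophenyl in place of 3-nitrophenyl gives an at least 6.1-fold lower number from compound 2 to compound 3 (0.78 log units; beyond the scatter). The earlier step from bromo to nitro therefore does not hold for every placement of the nitro group, since 4-nitrophenyl in place of 3-bromophenyl gives a 2.9-fold lower number from compound 1 to compound 3 (0.46 log units; beyond the scatter). The size of the change from 3-nitrophenyl stays open-ended, as compound 2 gives only a limit of the assay, not a number: the limit of > 50000 nM in this assay, at which 1 of the 3 values shown sits.

The compounds shown leave open whether the lower number of compound 3 belongs to the nitro group itself or to its place in 4-nitrophenyl. Bromo, an amine or a carboxylic acid in place of that nitro group would separate the two.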